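Oxindole sulfonamide series: cytotoxicity in HepG2 cells

The source may report more compounds than this note shows. Statements on the series, on what has been measured and on what is new or still open speak of the compounds shown alone.

Measured so far:
compound 1 `N#CCC(=O)N/N=C1\C(=O)Nc2ccc(S(=O)(=O)N3CCOCC3)cc21` — 7530 nM
compound 2 `O=C1Nc2ccc(S(=O)(=O)N3CCOCC3)cc2/C1=N/NS(=O)(=O)c1ccccc1` — 23900 nM
compound 3 `N=c1oc2ccccc2cc1C(=O)N/N=C1\C(=O)Nc2ccc(S(=O)(=O)N3CCOCC3)cc21` — 7820 nM

Working notes. In a functional assay on HepG2 cells (Homo sapiens) for cytotoxicity, read by sulforhodamine B assay, with a stated time of 24 h (a lower number here means a stronger inhibitor, a higher number a weaker inhibitor), compound 2 gives 23900 nM, the highest number of the three. Compound 1 and compound 3 sit close together, and the step of a 1.0-fold higher number from compound 1 to compound 3 (0.02 log units; within the scatter) is within the scatter, while a 3.2-fold higher number from compound 1 to compound 2 (0.50 log units; beyond the scatter) is beyond it.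

Compound 4 `O=C1Nc2ccc(S(=O)(=O)N3CCOCC3)cc2/C1=N/c1ccc(Cl)cc1` is not yet measured. The change from compound 2 is 4-chlorophenyl in place of (phenylsulfonyl)amino on a double-bonded nitrogen. Among the measured compounds shown here, no measured step covers this change directly; the nearest is a 3.2-fold higher number from compound 1 to compound 2 (0.50 log units; beyond the scatter), which shows that exchanging the group on the nitrogen of the shared core moves the number by a modest amount. The change to compound 4 removes the sulfonyl group entirely, so a modest shift is plausible, and the two other members of the series suggest a lower number is somewhat more likely than a higher one. The expected step is a 2.0-fold lower number from compound 2 to compound 4 (0.30 log units; within the scatter). For compound 4 the estimate in this assay is 12000 nM, with a range from 3500 nM to 40000 nM.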

Compound 4, half-maximal inhibitory concentration: 11800 nM
The estimate for compound 4 lay 1.0-fold (0.01 log units) above the measured number; measured number inside the range.
By their numbers in this assay, from the lowest: compounds 1, 3 and 4 (each within the scatter of the next); then compound 2.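

In this assay, the double-bonded nitrogen of the shared core accepts a directly attached 4-chlorophenyl group in place of (phenylsulfonyl)amino, and the step of a 2.0-fold lower number from compound 2 to compound 4 (0.31 log units; beyond the scatter) is modest. The sulfonyl-bearing group is therefore not needed for activity at this level, while a 1.6-fold higher number from compound 1 to compound 4 (0.20 log units; within the scatter) shows that 4-chlorophenyl and ((cyanomethyl)carbonyl)amino cannot be told apart at this position, even though they share little beyond their point of attachment. Nothing measured in this series accounts for either step.

As far as these compounds go, it remains open whether the chlorine itself matters, as an unsubstituted phenyl group on the same nitrogen would show. From the compounds shown here alone, it is also open whether an amine or a carboxylic acid on that phenyl ring, or a simple alkyl chain in its place, would move the number beyond the scatter.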